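Aryl swap on the carbonyl: compound 3 to compound 4

This account rests on a few compounds, and the source may have more. Where it says the series, first, only, none or still open, it means among the compounds named here.

In an ADME assay on HEK293 cells (Homo sapiens) for cytotoxicity, read by MTT assay, with a stated time of 72 h (a higher number here means a weaker inhibitor, a lower number a stronger inhibitor), compound 1 (`COc1ccc(C(=O)N2CCN(CC(=O)N3CCN(CCCc4c[nH]c5ccccc45)CC3)CC2)cc1`) gives 156000 nM, compound 2 (`O=C(CN1CCN(C(=O)c2ccc(F)cc2)CC1)N1CCN(CCCc2c[nH]c3ccccc23)CC1`) gives 141000 nM and compound 3 (`O=C(CN1CCN(C(=O)c2cccc(Cl)c2)CC1)N1CCN(CCCc2c[nH]c3ccccc23)CC1`) gives 99100 nM. Compound 3 therefore stands within the scatter of both other compounds, and the three numbers support no ranking.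

Compound 4 (`O=C(CN1CCN(C(=O)c2ccccc2F)CC1)N1CCN(CCCc2c[nH]c3ccccc23)CC1`) differs from compound 3 in one place: 2-fluorophenyl in place of 3-chlorophenyl on a carbonyl carbon. Going by the values given here, three measured steps bear on this change. The closest is a 1.4-fold lower number from compound 2 to compound 3 (0.15 log units; within the scatter), which also exchanges 3-chlorophenyl and a fluorophenyl group on a carbonyl carbon. The other two are a 1.1-fold lower number from compound 1 to compound 2 (0.04 log units; within the scatter) and a 1.6-fold lower number from compound 1 to compound 3 (0.20 log units; within the scatter). Among the compounds with values here, all three lie within the scatter, although no measured compound carries the 2-fluorophenyl group. No step beyond the scatter is therefore expected in this assay, and no direction is firmly indicated. The estimated step is a 1.2-fold higher number from compound 3 to compound 4 (0.08 log units; within the scatter). For compound 4, the estimated value is 120000 nM, with an expected range of 70000 nM to 200000 nM.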

Compound 4, half-maximal inhibitory concentration: 133000 nM
The estimate for compound 4 lay 1.1-fold (0.04 log units) below the measured number; measured number inside the range.
By their numbers in this assay, from the lowest: compounds 3, 4, 2 and 1 (each within the scatter of the next).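

At the carbonyl carbon, the 2-fluorophenyl group extends the flat picture in this assay to four aryl groups, with a 1.3-fold higher number from compound 3 to compound 4 (0.13 log units; within the scatter), a 1.1-fold lower number from compound 2 to compound 4 (0.03 log units; within the scatter) and a 1.2-fold lower number from compound 1 to compound 4 (0.07 log units; within the scatter). Moving from the earlier compounds to compound 4 therefore gives no ranking of the 2-fluorophenyl group against the 3-chlorophenyl, 4-fluorophenyl or 4-methoxyphenyl group, and the two fluorophenyl groups cannot be told apart here. No supporting measurement bears on why these numbers stay together.

Still open, as far as these compounds go, is whether an aryl group carrying an amine or a carboxylic acid at this carbonyl carbon would give a step beyond the scatter. A non-aromatic group such as cyclohexyl in place of the aryl group, or a longer chain elsewhere on the shared core, is equally unresolved.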